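Acetyl for isopropyl on a hydrazone series

The source may hold more compounds than are shown below. What is called first, only, known or untested is meant among the compounds shown, and "the series" means these compounds.

Compound 1 `COc1cc(/C=N/NC(=O)CCN2CCN(c3ccnc4cc(Cl)ccc34)CC2)ccc1OC(C)C` gives 8800 nM in an ADME assay on cells (Splenocyte, Mus musculus, strain BALB/c) for cytotoxicity, read by thymidine incorporation, with a stated time of 24 h (a higher number here means a weaker inhibitor, a lower number a stronger inhibitor), the second highest of three numbers. Compound 2 `COc1cc(/C=N/NC(=O)CCN2CCN(c3ccnc4cc(Cl)ccc34)CC2)c(Br)c(OC)c1OC` gives 9600 nM in this assay, and compound 3 `CC(C)c1ccc(/C=N/NC(=O)CCN2CCN(c3ccnc4cc(Cl)ccc34)CC2)cc1` gives 7900 nM; all three sit within the scatter of one another. The change to compound 4 `COc1cc(/C=N/NC(=O)CCN2CCN(c3ccnc4cc(Cl)ccc34)CC2)ccc1OC(C)=O` is acetyl in place of isopropyl on an oxygen on an aromatic ring. Among the compounds with values here, the only step that bears on it is a 1.1-fold lower number from compound 1 to compound 3 (0.05 log units; within the scatter), which exchanged the whole aryl group at the same end of the molecule and moved the number only within the scatter. The series shows no sensitivity at this position, so no step beyond the scatter is expected for compound 4, estimated at 8500 nM (range 4000 nM to 18000 nM), a step of a 1.0-fold lower number from compound 1 to compound 4 (0.02 log units; within the scatter).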

Compound 4, half-maximal inhibitory concentration: 15800 nM
Compound 4: middle estimate off by 1.9-fold (0.27 log units), on the low side; low and high end bracket the measured number.
By their numbers in this assay, from the lowest: compounds 3, 1, 2 and 4 (each within the scatter of the next).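

In this assay, acetyl in place of isopropyl on this oxygen gives a 1.8-fold higher number from compound 1 to compound 4 (0.25 log units; within the scatter), and the wider exchange gives a 2.0-fold higher number from compound 3 to compound 4 (0.30 log units; within the scatter). Within the data shown here, both steps stay within the scatter, so the position tolerates a change that brings in a carbonyl and a hydrogen-bond acceptor, which the earlier compounds had not tested on this oxygen. Nothing available accounts for these numbers. On these data alone, whether an aminoethyl or a carboxymethyl group on this oxygen, or a longer chain such as hexyl, would give a step beyond the scatter remains open.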